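This account rests on a few compounds, and the source may have more. Where it says the series, first, only, none or still open, it means among the compounds named here.

Measured so far:
compound 1, `O=C(O)c1cccc(Cc2c(-c3ccccc3)nn3ccccc23)n1`, 2300 nM
compound 2, `O=C(O)c1cccc(Cc2c(-c3cccc(Cl)c3)nn3cc(Cl)ccc23)n1`, 480 nM

Both compounds were tested in a functional assay on cells for antagonist activity at prostaglandin E2 receptor EP1 subtype (Rattus norvegicus), read by fluorescence and calcium flux, with a stated time of 60 s; a higher number here means a weaker inhibitor, a lower number a stronger inhibitor. Of these two numbers compound 2 stands lowest, with 480 nM. Its nearest neighbour is compound 1, whose value of 2300 nM is the higher one, and that gap lies beyond the usual scatter of repeated measurements. Among the measured compounds shown here, the two structures differ in more than one place, so no single step between measured compounds can be read off here.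

Compound 3, `O=C(O)c1cccc(Cc2c(-c3ccoc3)nn3cc(Cl)ccc23)n1`, has not yet been measured. It is derived from compound 2 by one change: furan-3-yl in place of 3-chlorophenyl on an aromatic carbon. For the measured compounds named here, no measured pair isolates this exchange, so its effect is not known from the data. Going by the values given here, the only comparison at hand is compound 1, which in this assay gives 2300 nM, a higher number than compound 2, and it suggests that moving away from compound 2 in this part of the molecule tends to raise the number. A moderate rise, beyond the scatter, is therefore expected: a 3.1-fold higher number from compound 2 to compound 3 (0.49 log units; beyond the scatter) in this assay. Compound 3 is estimated to give about 1500 nM, with a range from 500 nM to 4500 nM.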

Compound 3, half-maximal inhibitory concentration: 130 nM
Estimate against measurement, compound 3: 12-fold (1.06 log units) above; the whole stated range lies above it.
By their numbers in this assay, from the lowest: compound 3; then compound 2; then compound 1.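

In this assay, among the compounds shown here, the exchange of 3-chlorophenyl for furan-3-yl gives a 3.7-fold lower number from compound 2 to compound 3 (0.57 log units; beyond the scatter), and this is the only comparison here in which just one place on the molecule differs. It shows that this position, on the five-membered aromatic ring with 2 nitrogen, does not depend on a six-membered carbon ring carrying chlorine: a smaller group of 5 heavy atoms, with an oxygen in its ring and no chlorine, gives the stronger inhibitor of the pair. The data offer no measurement that explains why this change lowers the number.

Three things change together in this one step (ring size, the ring oxygen and the loss of chlorine), so their separate contributions remain unresolved. Compound 1 differs from compound 2 in more than one place. It cannot help here. Also open, as far as these compounds go, is how far this position accepts other groups, such as a thiophene, a pyridine or a cyclopropyl ring, and whether the chlorine on the shared core matters to the value of compound 3 at all.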